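The compounds below may be only part of what the source reports. "The series", "measured", "known", "first", "only" and "open" are said of these compounds alone.

Working notes on the series, read in a functional assay on MCF7 cells (Homo sapiens) for inhibition, read by MTT assay, with a stated time of 48 h; a higher number here means a weaker inhibitor, a lower number a stronger inhibitor. For the measured compounds named here, compound 1 (`COc1ccc(-c2nc3c(c(-c4ccccc4)nn3-c3ccccc3)c(-c3ccc(N4CCCCC4)cc3)c2C#N)cc1`) gives 2760 nM, the second highest of the three numbers so far. Compound 2 (`COc1ccc(C(=O)C=CNc2cc(-c3ccccc3)nn2-c2ccccc2)cc1`) gives 1290 nM, the nearest value, and compound 3 (`c1ccc(-c2nn(-c3ccccc3)c3nccc(-c4cccs4)c23)cc1`) gives 39300 nM, the furthest, both gaps lying beyond the scatter. Compound 4 (`N#Cc1c(-c2ccccc2)nc2c(c(-c3ccccc3)nn2-c2ccccc2)c1-c1ccc(N2CCCCC2)cc1`) keeps the core of compound 1 and carries hydrogen in place of methoxy on an aromatic carbon, 4-methoxyphenyl to phenyl: hydrogen in place of methoxy on an aromatic carbon. Going by the values given here, no measured pair shows this change, so any expectation for it remains weakly supported. The expected step of a 1.2-fold higher number from compound 1 to compound 4 (0.08 log units; within the scatter) is small, toward a slightly higher number, and not expected to pass the scatter. For compound 4 the estimated value is 3300 nM, within an expected range of 1100 nM to 10000 nM.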

Compound 4, half-maximal inhibitory concentration: 27000 nM
Compound 4: middle estimate off by 8.2-fold (0.91 log units), on the low side; the measured number lies above the stated range.
By their numbers in this assay, from the lowest: compound 2; then compound 1; then compounds 4 and 3 (each within the scatter of the next).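

For the compounds shown here, this is the first measured pair at this position, and the position proves not to be indifferent in this assay: going from 4-methoxyphenyl to phenyl gives a 9.8-fold higher number from compound 1 to compound 4 (0.99 log units; beyond the scatter). On the core of compound 1, the methoxy on an aromatic carbon, para to a large group, therefore carries real weight for a change of only 2 heavy atoms. Nothing measured here accounts for the step.

From the compounds shown here alone, with a single pair, it remains open whether the difference belongs to methoxy specifically or would also appear with another group at this place, such as hydroxyl, ethoxy or a fluorine atom. Going by these compounds, whether it holds on any other core also remains open.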